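The source may hold more compounds than are shown below. What is called first, only, known or untested is meant among the compounds shown, and "the series" means these compounds.

Values in an ADME assay on HepG2 2.2.15 cells (Homo sapiens) for cytotoxicity (on this read-out lower numbers stand for higher toxicity in this test and higher numbers for lower toxicity in this test), for the series:
compound 1 `CC(C)C(=O)OCCc1c(-c2ccccc2Cl)c2cc(Cl)ccc2[nH]c1=O` gives 62000 nM
compound 2 `CCOCC(=O)OCCc1c(-c2ccccc2Cl)c2cc(Cl)ccc2[nH]c1=O` gives 130000 nM
compound 3 `O=C(OCCc1c(-c2ccccc2Cl)c2cc(Cl)ccc2[nH]c1=O)c1cccnc1` gives 170000 nM

Compound 3 is level with compound 2 within the scatter (a 1.3-fold higher number from compound 2 to compound 3 (0.12 log units; within the scatter)) and stands clear of compound 1 (a 2.7-fold higher number from compound 1 to compound 3 (0.44 log units; beyond the scatter)). The next compound is compound 4 `COc1ccccc1/C=C/C(=O)OCCc1c(-c2ccccc2Cl)c2cc(Cl)ccc2[nH]c1=O`, in which 2-(2-methoxyphenyl)ethenyl stands in place of pyridin-3-yl on a carbonyl carbon (2-(2-methoxyphenyl)ethenyl in place of pyridin-3-yl on a carbonyl carbon).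

Only changes on this same carbonyl carbon bear on the step. Two were modest (a 2.1-fold higher number from compound 1 to compound 2 (0.32 log units; beyond the scatter); a 2.7-fold higher number from compound 1 to compound 3 (0.44 log units; beyond the scatter)), and one stayed within the scatter (a 1.3-fold higher number from compound 2 to compound 3 (0.12 log units; within the scatter)). For the measured compounds named here, no measured compound carries an ethenyl group or a carbon-only aromatic ring at this place, so the direction rests on thin ground. Compound 3, at 170000 nM, stands at the high end of the three numbers, so a small fall is expected rather than a rise.

In this assay the expected step is small (a 1.7-fold lower number from compound 3 to compound 4 (0.23 log units; within the scatter)).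
For compound 4 the estimate is 100000 nM, with an expected range from 40000 nM to 220000 nM.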

Compound 4, half-maximal cytotoxic concentration: 770000 nM
The estimate for compound 4 lay 7.7-fold (0.89 log units) below the measured number; measured number above the stated range.
By their numbers in this assay, from the lowest: compound 1; then compounds 2 and 3 (each within the scatter of the next); then compound 4.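

Working from this assay, the earlier groups at this carbonyl carbon gave only modest steps, whereas 2-(2-methoxyphenyl)ethenyl lifts the number clear of all three: (a 4.5-fold higher number from compound 3 to compound 4 (0.66 log units; beyond the scatter)), (a 5.9-fold higher number from compound 2 to compound 4 (0.77 log units; beyond the scatter)) and (a 12-fold higher number from compound 1 to compound 4 (1.09 log units; beyond the scatter)). For the compounds shown here, this place can therefore move the read-out further than the first three compounds suggested, and the highest number comes with a carbon-only aromatic ring and a double bond outside aromatic rings, the first such group here. No measurement available on these compounds bears on why the number rises.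

Since compound 4 brings in the ethenyl link, the carbon-only ring and the methoxy group together, the compounds shown do not separate their contributions. Going by these compounds, how an amine or a carboxylic acid on this carbonyl carbon would read also remains open.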